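The compounds below may be only part of what the source reports. "The series", "measured", "known", "first", "only" and "open" are said of these compounds alone.

Measured compounds:
Compound 1 `CC(C)(C)c1ccc(C(=O)N2CCC3(CC2)C(=O)N(CC(=O)N2CCCC(CO)C2)CN3c2ccccc2)cc1` gives 8200 nM in an assay on HEK293 cells for displacement of a labelled ligand from NPC1-like intracellular cholesterol transporter 1 (Homo sapiens); a higher number here means a weaker inhibitor, a lower number a stronger inhibitor.
Compound 2 `CC(C)(C)c1ccc(C(=O)N2CCC3(CC2)C(=O)N(CC(=O)N2CCC(O)CC2)CN3c2ccccc2)cc1` gives 4700 nM in this assay.
Compound 3 `COC(=O)CCCNC(=O)CN1CN(c2ccccc2)C2(CCN(C(=O)c3ccc(C(C)(C)C)cc3)CC2)C1=O` gives "not determined" (no result reported) in this assay, so no number stands for it.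

Compound 4 `CC(C)(C)c1ccc(C(=O)N2CCC3(CC2)C(=O)N(CC(=O)N2CCCC(C(N)=O)C2)CN3c2ccccc2)cc1` is the compound still to be tested. It differs from compound 3 in one place: 3-carbamoylpiperidin-1-yl in place of (3-(methoxycarbonyl)propyl)amino on a carbonyl carbon. For the measured compounds named here, since compound 3 has no result, no step from it can be quantified. Going by the values given here, the only measured step, a 1.7-fold lower number from compound 1 to compound 2 (0.24 log units; within the scatter), exchanges one substituted six-membered ring amide for another and lies within the scatter; compound 4 carries a ring of that kind, 3-carbamoylpiperidin-1-yl, so compound 4 is expected to land near compound 1 and compound 2 in this assay. The estimated value for compound 4 is 6000 nM, with a range from 2000 nM to 20000 nM.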

Compound 4, half-maximal inhibitory concentration: 16900 nM
Beside the measured number, compound 4's estimate is 2.8-fold (0.45 log units) below it; measured number inside the range.
By their numbers in this assay, from the lowest: compounds 2 and 1 (each within the scatter of the next); then compound 4.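

In this assay, carbamoyl in place of hydroxymethyl on a saturated ring carbon gives a 2.1-fold higher number from compound 1 to compound 4 (0.31 log units; beyond the scatter), and 3-carbamoylpiperidin-1-yl in place of 4-hydroxypiperidin-1-yl gives a 3.6-fold higher number from compound 2 to compound 4 (0.56 log units; beyond the scatter). Both steps are modest, but they show that substituted six-membered ring amides on this carbonyl carbon do not all lie within the scatter of one another, with the carbamoyl-bearing compound 4 apart from both hydroxyl-bearing compounds. Nothing shown accounts for this difference. The step from compound 3 cannot be read, so the open chain gives no comparison with the ring. On these data alone, whether an amine or a carboxylic acid on the same piperidine ring would sit with compound 4 or with the hydroxyl-bearing compounds stays open.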